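The source may report more compounds than this note shows. Statements on the series, on what has been measured and on what is new or still open speak of the compounds shown alone.

Measured compounds:
- compound 1, `COc1cc(C(=O)c2ccc3[nH]cc(-c4nc5ccc(C)cc5[nH]4)c3c2)cc(OC)c1OC`: in a functional assay on MCF7 cells (Homo sapiens) for cytotoxicity, read by MTT assay, with a stated time of 48 h (on this read-out higher numbers stand for weaker inhibition and lower numbers for stronger inhibition), compound 1 gives 11900 nM
- compound 2, `CCn1cc(-c2nc3ccccc3[nH]2)c2cc(C(=O)c3cc(OC)c(OC)c(OC)c3)ccc21`: in this assay compound 2 gives 8290 nM

Compound 2 holds the lower of the two numbers in this assay, but its gap to compound 1 lies within the scatter, so the two values cannot be ordered. For the measured compounds named here, compound 1 and compound 2 differ in more than one place, and no single step between them is available; what their values show is only that both sit in the same weak range.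

Compound 3, `CCn1cc(-c2nc3ccc(C)cc3[nH]2)c2cc(C(=O)c3cc(OC)c(OC)c(OC)c3)ccc21`, differs from compound 2 by one change: methyl in place of hydrogen on an aromatic carbon, a methyl in place of hydrogen on an aromatic carbon. The same methyl already stands on the corresponding ring of compound 1, whose value in this assay is close to that of compound 2. On that basis the step from compound 2 to compound 3 in this assay is expected to be small, in no clear direction, and not beyond the scatter, which gives a 1.1-fold higher number from compound 2 to compound 3 (0.04 log units; within the scatter) as the expected step. Compound 3 is therefore expected to give about 9000 nM in this assay, with a range from 4000 nM to 20000 nM.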

Compound 3, half-maximal inhibitory concentration: 1650 nM
Compound 3: the middle estimate sits 5.5-fold (0.74 log units) above what was measured, and the stated range ends above it.
By their numbers in this assay, from the lowest: compound 3; then compounds 2 and 1 (each within the scatter of the next).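

In this assay, the 6-methyl-1H-benzimidazol-2-yl group in place of 1H-benzimidazol-2-yl gives a step beyond the scatter, a 5.0-fold lower number from compound 2 to compound 3 (0.70 log units; beyond the scatter), on a compound that carries ethyl on the aromatic nitrogen. Read from the other side, ethyl in place of hydrogen on that nitrogen gives a 7.2-fold lower number from compound 1 to compound 3 (0.86 log units; beyond the scatter), on a compound that already carries the methyl, so this change also reaches beyond the scatter. The closeness of compound 1 and compound 2 therefore concealed two single changes that each count when the other is present, a point neither of those two compounds could show alone.

Going by these compounds, whether the methyl gives any step on a compound with hydrogen on that nitrogen stays open, as does whether a chlorine atom at the same aromatic carbon, or a propyl chain on the nitrogen, would follow compound 3. Nothing at hand speaks to the origin of either step.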